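Halogen swap on a fused core: chloro to bromo

A few compounds are considered here, and "the series" means these few. Any claim that something is new, unique, unknown or untested is made for them only; others in the source may bear on it.

Measured compounds:
compound 1 `Cc1[nH]c2ccc(Br)cc2c(=O)c1Br`: 1.76
compound 2 `Cc1[nH]c2ccc(Cl)cc2c(=O)c1Br`: 2.02
compound 3 `CCc1c(C)[nH]c2cc(OC)c(Cl)cc2c1=O`: 2.43

The study concerns three measured compounds and one that still awaits measurement. In a physicochemical assay for lipophilicity, at pH 7.4 (on this read-out higher numbers stand for higher lipophilicity and lower numbers for lower lipophilicity), compound 1 gives 1.76. Compound 2 gives 2.02 in this assay, and compound 3 gives 2.43. Compound 3 stands highest of the three, beyond the scatter from both others; how the core of compound 3 differs from that of compound 2 is not broken down here.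

Compound 2 and compound 1 differ in one place only: bromo in place of chloro on an aromatic carbon. That change made a step of a number 0.26 log units lower from compound 2 to compound 1 (within the scatter).

The unmeasured compound 4 `CCc1c(C)[nH]c2cc(OC)c(Br)cc2c1=O` stands to compound 3 as compound 1 stands to compound 2: bromo in place of chloro on an aromatic carbon. The two places are not the same word for word, since in compound 4 the new bromo sits ortho to a methoxy group, a neighbour that the place in compound 1 lacks; it is the same kind of change, not the same change. Going by the values given here, because the step from compound 2 to compound 1 was a number 0.26 log units lower from compound 2 to compound 1 (within the scatter), a step of similar size is expected from compound 3 to compound 4, namely a number 0.13 log units lower from compound 3 to compound 4 (within the scatter), though with only one earlier example this rests on thin ground. Compound 4 is therefore estimated at 2.3 in this assay, expected to fall between 1.95 and 2.7.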

Compound 4, distribution coefficient: 1.7
Compound 4: middle estimate off by 0.60 log units, on the high side, outside the stated range (below it).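

In this assay, going by these compounds alone, bromo in place of chloro on an aromatic carbon gave a number 0.73 log units lower from compound 3 to compound 4 (beyond the scatter), while the same kind of change on the core of compound 2 gave a number 0.26 log units lower from compound 2 to compound 1 (within the scatter), so the one step lies beyond the scatter and the other within it. This shows that, across these two pairs, the size of the step seen on one core did not carry over to the other, and that the earlier pair was a poor guide to the later one. It does not show what sets the two steps apart: the new bromo in compound 4 is ortho to a methoxy group, a neighbour that the bromo in compound 1 lacks, but the cores also differ elsewhere, two pairs cannot separate these differences, and nothing at hand bears on the reason for the result.

As far as these compounds go, what a fluoro or a nitrile would give on that same aromatic carbon of the core of compound 3 remains open, and so does whether the step would hold its size there. Also open, from the compounds shown here alone, is how the same chloro to bromo change would read out with a hydroxy group or an amine in place of the methoxy group.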